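Swapping the imine substituent in a quinolinone series

A few compounds are considered here, and "the series" means these few. Any claim that something is new, unique, unknown or untested is made for them only; others in the source may bear on it.

Measured compounds:
- compound 1 `O=c1[nH]c2ccccc2cc1/C=N/c1ccccc1O`: 1660000 nM
- compound 2 `Cc1ccc2[nH]c(=O)c(/C=N/c3ccccc3O)cc2c1`: 1350000 nM
- compound 3 `NS(=O)(=O)c1ccc(/N=C/c2cc3ccccc3[nH]c2=O)cc1`: 266000 nM

In a functional assay, read by spectrophotometry, with a stated time of 1 h (on this read-out lower numbers stand for stronger inhibition and higher numbers for weaker inhibition), compound 2 gives the second highest of the three numbers; compound 1 sits within the scatter of it, as the step of a 1.2-fold lower number from compound 1 to compound 2 (0.09 log units; within the scatter) shows, while compound 3 gives a clearly lower number. Compound 4 `Cc1ccc2[nH]c(=O)c(/C=N/CCO)cc2c1` differs from compound 2 by 2-hydroxyethyl in place of 2-hydroxyphenyl on a double-bonded nitrogen. Among the measured compounds shown here, no measured step bears on this change: the only step seen, from compound 1 to compound 2, alters a methyl elsewhere. Compounds 1 and 3 show that what sits on the double-bonded nitrogen can move this assay strongly, but in which direction a 2-hydroxyethyl group would act cannot be read from them. Compound 4 is therefore expected near compound 2, with wide uncertainty, an expected step of a 1.5-fold higher number from compound 2 to compound 4 (0.17 log units; within the scatter) and an estimate of 2000000 nM (range 500000 nM to 8000000 nM).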

Compound 4, half-maximal inhibitory concentration: 4180000 nM
For compound 4 the middle estimate is 2.1-fold (0.32 log units) below the measured one; low and high end bracket the measured number.
By their numbers in this assay, from the lowest: compound 3; then compounds 2 and 1 (each within the scatter of the next); then compound 4.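

In this assay, among the compounds shown here, the first direct step at this position, a 3.1-fold higher number from compound 2 to compound 4 (0.49 log units; beyond the scatter), shows that 2-hydroxyethyl on the double-bonded nitrogen gives weaker inhibition than 2-hydroxyphenyl. The change removes the aromatic ring, while the counts of hydrogen-bond donors and acceptors stay the same. Nothing available accounts for this step.

Open, from the compounds shown here alone, is how a plain phenyl, a longer chain ending in a hydroxyl, or a 2-aminoethyl group would read on that nitrogen. Also open, going by these compounds, is whether the same swap would give a similar step on the core of compound 1.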